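Series notes: replacing the benzyl group on the ring nitrogen

The compounds below may be only part of what the source reports. "The series", "measured", "known", "first", "only" and "open" are said of these compounds alone.

Measured so far in a functional assay on CHO cells for antagonist activity at growth hormone secretagogue receptor type 1 (Homo sapiens); on this read-out lower numbers stand for stronger inhibition and higher numbers for weaker inhibition:
- compound 1 `COc1ccc(Cn2c(CCc3c[nH]c4ccccc34)nnc2[C@H](NC(=O)C(C)(C)N)c2c[nH]c3ccccc23)c(OC)c1`: 14 nM
- compound 2 `COc1ccc(Cn2c(CCc3c[nH]c4ccccc34)nnc2[C@H](NC(=O)c2ccccn2)c2c[nH]c3ccccc23)c(OC)c1`: 19 nM
- compound 3 `COc1ccc(Cn2c(CCc3ccccc3)nnc2[C@H](NC(=O)c2ccccn2)c2c[nH]c3ccccc23)c(OC)c1`: 25 nM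

Compound 2 stands second highest of the three numbers. Its nearest neighbour is compound 3, and the step from compound 2 to compound 3 is a 1.3-fold higher number from compound 2 to compound 3 (0.12 log units; within the scatter), which concerns phenyl in place of 1H-indol-3-yl on the saturated chain carbon. The step from compound 1 to compound 2, pyridin-2-yl in place of 1-amino-1-methylethyl on the carbonyl carbon, is a 1.4-fold higher number from compound 1 to compound 2 (0.13 log units; within the scatter). Both changes leave the read-out essentially where it was.

Compound 4 `CCc1ccc(-n2c(CCc3c[nH]c4ccccc34)nnc2[C@H](NC(=O)c2ccccn2)c2c[nH]c3ccccc23)cc1` differs from compound 2 at a different place: 4-ethylphenyl in place of 2,4-dimethoxybenzyl on an aromatic nitrogen. All three measured compounds carry the 2,4-dimethoxybenzyl group on that aromatic nitrogen, so neither measured step bears on this change; the two steps that do exist, at the carbonyl carbon and the saturated chain carbon, were each within the scatter. The series therefore gives no direct guidance on the size or direction of the step to compound 4, and the expectation rests on the measured range alone, widened for the untested position.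

The step from compound 2 to compound 4 is expected to be a 2.1-fold higher number from compound 2 to compound 4 (0.32 log units; beyond the scatter). Compound 4 is estimated at 40 nM in this assay, with a range from 10 nM to 160 nM.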

Compound 4, antagonist equilibrium constant: 129 nM
The estimate for compound 4 lay 3.2-fold (0.51 log units) below the measured number; low and high end bracket the measured number.
By their numbers in this assay, from the lowest: compounds 1, 2 and 3 (each within the scatter of the next); then compound 4.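

For the compounds shown here, on the aromatic nitrogen of the five-membered ring, 4-ethylphenyl in place of 2,4-dimethoxybenzyl gives a 6.8-fold higher number from compound 2 to compound 4 (0.83 log units; beyond the scatter) in this assay and is the first step in this set to lie beyond the scatter. This position therefore responds to substitution in a way that the steps at the carbonyl carbon and the saturated chain carbon, each within the scatter, did not show. The change takes the substituent from 11 heavy atoms to 8 and from 2 hydrogen-bond acceptors to 0, and it also removes the benzyl link to the ring nitrogen, but no measurement here ties the step to any one of these differences.

Going by these compounds alone, the single step cannot separate the loss of the link from the exchange of ring substituents, so a 4-ethylbenzyl group and a 2,4-dimethoxyphenyl group on the same nitrogen would be the informative comparisons. Also open, going by these compounds, is whether a plain benzyl group or a longer chain such as 2-phenylethyl on that nitrogen would keep the number near that of compound 2 at 19 nM in this assay.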